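From Methoxy to Pyridin-3-yl: an Expected Step

This account rests on a few compounds, and the source may have more. Where it says the series, first, only, none or still open, it means among the compounds named here.

Compound 1 `CC(C)(N)C(=O)N[C@H](COCc1ccccc1Cl)c1nnnn1CCOC(=O)NCCCCO` gives 0.45 nM in a functional assay on cells for inhibition of growth hormone secretagogue receptor type 1 (Homo sapiens), read by FLIPR and calcium flux; on this read-out lower numbers stand for an effect already at smaller amounts and higher numbers for an effect only at larger amounts of compound.
Compound 2 `Cc1ccccc1COC[C@@H](NC(=O)C(C)(C)N)c1nnnn1CCOC(=O)NCCCCO` gives 0.51 nM in this assay.
Compound 3 `COc1ccccc1COC[C@@H](NC(=O)C(C)(C)N)c1nnnn1CCOC(=O)NCCCCO` gives 1.11 nM in this assay.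

Among the three measured compounds, compound 3 carries the highest number: the steps of a 2.5-fold higher number from compound 1 to compound 3 (0.39 log units; beyond the scatter) and a 2.2-fold higher number from compound 2 to compound 3 (0.34 log units; beyond the scatter) both lie beyond the scatter, whereas the step of a 1.1-fold higher number from compound 1 to compound 2 (0.05 log units; within the scatter) does not. Compound 4 `CC(C)(N)C(=O)N[C@H](COCc1ccccc1-c1cccnc1)c1nnnn1CCOC(=O)NCCCCO` differs from compound 3 in a single place: pyridin-3-yl in place of methoxy on an aromatic carbon. The measured steps that bear on this change are the two exchanges of the group on that aromatic carbon, a 2.5-fold higher number from compound 1 to compound 3 (0.39 log units; beyond the scatter) and a 2.2-fold higher number from compound 2 to compound 3 (0.34 log units; beyond the scatter); both were modest, and neither involved a group as large as pyridin-3-yl. The data therefore give no direct guide to a ring entering at this place, and the direction of the new step is uncertain. On this basis only a small step is expected, a 1.4-fold higher number from compound 3 to compound 4 (0.13 log units; within the scatter), with a wide range around it. Compound 4 is accordingly estimated at 1.5 nM, with a range from 0.4 nM to 6 nM.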

Compound 4, half-maximal effective concentration: 1.18 nM
Beside the measured number, compound 4's estimate is 1.3-fold (0.10 log units) above it; the range from low to high includes it.
By their numbers in this assay, from the lowest: compounds 1 and 2 (each within the scatter of the next); then compounds 3 and 4 (each within the scatter of the next).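

At this aromatic carbon, ortho to a large group, a six-membered aromatic ring is tolerated in this assay: the step of a 1.1-fold higher number from compound 3 to compound 4 (0.03 log units; within the scatter) shows that pyridin-3-yl, with 6 heavy atoms, can stand in place of methoxy, with 2, without a change beyond the scatter. Measured against the smaller groups, the steps of a 2.3-fold higher number from compound 2 to compound 4 (0.36 log units; beyond the scatter) for methyl and a 2.6-fold higher number from compound 1 to compound 4 (0.42 log units; beyond the scatter) for chloro are both beyond the scatter yet remain modest, so the largest group shown here costs little in this assay. Nothing measured in the material at hand accounts for this tolerance.

From the compounds shown here alone, whether the ring nitrogen matters remains open, since a plain phenyl ring cannot be compared with pyridin-3-yl here. Going by these compounds, it is equally open whether pyridin-4-yl, an aminomethyl group or a carboxylic acid at this carbon would keep the number in the same range.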